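The source may hold more compounds than are shown below. What is called first, only, known or untested is meant among the compounds shown, and "the series" means these compounds.

Working notes on the series. Compound 1 `CCN(CC)CN1C(=O)/C(=N\NC(=S)NO)c2cc(Cl)ccc21` gives 562000 nM in an ADME assay on MT4 cells (Homo sapiens) for cytotoxicity, read by spectrophotometry, with a stated time of 5 days (on this read-out higher numbers stand for lower toxicity in this test and lower numbers for higher toxicity in this test), and compound 2 `CN(C)CN1C(=O)/C(=N\NC(=S)NO)c2cc(F)ccc21` gives 599000 nM. Compound 3 `CCn1cc(C(=O)O)c(=O)c2cc(F)c(N3CCN(CN4C(=O)/C(=N\NC(=S)NO)c5cc(Cl)ccc54)CC3)cc21` gives 186000 nM; on these three numbers compound 3 stands lowest, below both compound 1 and compound 2 by margins beyond the usual scatter. For the measured compounds named here, no step between two measured compounds differs in only one place, so the series offers no direct read on any single change.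

Compound 4 `CCn1cc(C(=O)O)c(=O)c2cc(F)c(N3CCN(CN4C(=O)/C(=N\NC(=S)NO)c5cc(C)ccc54)CC3)cc21` has not been measured. It differs from compound 3 as follows: methyl in place of chloro on an aromatic carbon. Going by the values given here, with no comparable step measured, the change from compound 3 to compound 4 is expected to give a 1.1-fold higher number from compound 3 to compound 4 (0.05 log units; within the scatter), that is, nothing beyond the scatter. For compound 4 the estimated value is 210000 nM, with a range of 100000 nM to 420000 nM.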

Compound 4, half-maximal cytotoxic concentration: 327000 nM
For compound 4 the middle estimate is 1.6-fold (0.19 log units) below the measured one; low and high end bracket the measured number.
By their numbers in this assay, from the lowest: compounds 3, 4, 1 and 2 (each within the scatter of the next, the first and the last beyond it).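

Methyl in place of chloro on an aromatic carbon is the first step in the series that differs in only one place, and in this assay it gives a 1.8-fold higher number from compound 3 to compound 4 (0.25 log units; within the scatter). At this position, with the rest of compound 3 held constant, the two groups are therefore not told apart. Nothing available speaks to the reason for this result.

Open, from the compounds shown here alone, is whether a methoxy group or an amine on this aromatic carbon would give a step beyond the scatter. Also open, going by these compounds, is whether methyl in place of chloro reads the same on the core of compound 1.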